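Compound 1 to compound 3: an added carboxy-pyrrolidine

The source may report more compounds than this note shows. Statements on the series, on what has been measured and on what is new or still open speak of the compounds shown alone.

For the measured compounds named here, in a physicochemical assay for solubility, read by HPLC, in phosphate buffer, at pH 6.5 (a higher number here means a more soluble compound, a lower number a less soluble compound), compound 1 (`COC(=O)C1=C(C)NC(c2nccs2)=N[C@H]1c1ccc(F)cc1Cl`) gives 16 ug/mL and holds the lower of the two numbers so far. Compound 2 (`COC(=O)C1=C(C)NC(N2CCOCC2)=N[C@H]1c1ccc(F)cc1Cl`) gives 195 ug/mL with morpholin-4-yl in place of 1,3-thiazol-2-yl. That step (a 12-fold higher number from compound 1 to compound 2 (1.09 log units; beyond the scatter)) is large, beyond the scatter, and the only one measured. Compound 3 (`COC(=O)C1=C(CN2CC(C)(C)C[C@H]2C(=O)O)NC(c2nccs2)=N[C@H]1c1ccc(F)cc1Cl`) keeps the 1,3-thiazol-2-yl of compound 1 and differs elsewhere (2-carboxy-4,4-dimethylpyrrolidin-1-yl in place of hydrogen on a saturated chain carbon bound to a double-bonded ring carbon): 2-carboxy-4,4-dimethylpyrrolidin-1-yl in place of hydrogen on a saturated chain carbon bound to a double-bonded ring carbon. Going by the values given here, no measured step covers this place, so the step to compound 2 (a 12-fold higher number from compound 1 to compound 2 (1.09 log units; beyond the scatter)) serves only as a loose guide to size. A step of similar size towards a higher number is expected (a 13-fold higher number from compound 1 to compound 3 (1.10 log units; beyond the scatter)). For compound 3 the estimate in this assay is 200 ug/mL with an expected range from 40 ug/mL to 1000 ug/mL for now.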

Compound 3, solubility: > 644 ug/mL
Compound 3 ended at the assay's limit (the forecaster's own chance of this, stated with the estimate: 10%); middle value at least 3.2-fold (0.50 log units) from the limit.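

In this assay compound 3 gives > 644 ug/mL, which is a limit of the assay and not a number. With 2-carboxy-4,4-dimethylpyrrolidin-1-yl in place of hydrogen, the series shows an at least 40-fold higher number from compound 1 to compound 3 (1.60 log units; beyond the scatter), a large step with the 1,3-thiazol-2-yl kept. The earlier compounds shown here gave a step only on the carbon with a double bond to nitrogen, so the saturated chain carbon bound to a double-bonded ring carbon is a second place where one change moves the read-out well beyond the scatter.

As far as these compounds go, it remains open whether this step follows the carboxylic acid or the pyrrolidine amine, which the methyl ester of the same group or a plain pyrrolidin-1-yl on that carbon would separate. Also open, from the compounds shown here alone, is how morpholin-4-yl and 2-carboxy-4,4-dimethylpyrrolidin-1-yl behave together in one compound.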